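A methyl on the triazole of compound 2

The source may hold more compounds than are shown below. What is called first, only, known or untested is meant among the compounds shown, and "the series" means these compounds.

Measured in an ADME assay on microsomes from liver (Rattus norvegicus) for metabolic stability (on this read-out higher numbers stand for a longer-lived compound and lower numbers for a shorter-lived compound), so far
Compound 1 `CCC(CC)(c1nnc[nH]1)c1ccc(-c2ccc3cc(F)cc(F)c3c2)[nH]c1=O` gives 1.26 h 
Compound 2 `CCn1ncc2c(F)cc(-c3ccc(C(CC)(CC)c4nnc[nH]4)c(=O)[nH]3)cc21` gives > 3 h 
Compound 3 `CC(C)C(Cc1nnc[nH]1)c1ccc(-c2ccc3cccc(F)c3c2)[nH]c1=O` gives 0.1 h 

Compound 2 gives > 3 h as a limit of the assay and not a number. It thus stands at the limit of > 3 h in this assay, at which 1 of the 3 values shown sits, and has no exact value here.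

Compound 4 `CCn1ncc2c(F)cc(-c3ccc(C(CC)(CC)c4ncn(C)n4)c(=O)[nH]3)cc21` differs from compound 2 in one place 1-methyl-1H-1,2,4-triazol-3-yl in place of 4H-1,2,4-triazol-3-yl on a saturated chain carbon bound to an aromatic carbon and two saturated chain carbons with 1-methyl-1H-1,2,4-triazol-3-yl in place of 4H-1,2,4-triazol-3-yl on a saturated chain carbon bound to an aromatic carbon and two saturated chain carbons. Among the compounds with values here, all three measured compounds carry the 4H-1,2,4-triazol-3-yl group, so no measured pair shows what this swap does.

Compound 1 gives 1.26 h and compound 3 gives 0.1 h with different groups elsewhere, so values in this series can lie far apart, and the expected range has to stay wide. The expected step is an at least 1.2-fold lower number from compound 2 to compound 4 (0.07 log units; that floor lies within the scatter) and it is expected to be small, towards a shorter-lived compound. For compound 4 the estimate in this assay is 2.5 h with an expected range from 1 h to 6 h and a limit of the assay is also possible.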

Compound 4, half-life: > 3 h
Compound 4: no number, only a limit; the forecaster's own chance of this, stated with the estimate: 45%; middle value at least 1.2-fold (0.07 log units) away from the limit.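

Compound 2 and compound 4 both give a limit of the assay and not a number, so the step from one to the other cannot be read in this assay: the limit of > 3 h in this assay, at which 2 of the 4 values shown sit.

The compounds shown leave open how long either compound really lasts, and so whether 1-methyl-1H-1,2,4-triazol-3-yl in place of 4H-1,2,4-triazol-3-yl changes the half-life at all.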